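Compound 4 in the antiproliferative assay: an estimate before measurement

A few compounds are considered here, and "the series" means these few. Any claim that something is new, unique, unknown or untested is made for them only; others in the source may bear on it.

Measured so far:
compound 1, `COc1ccc(-c2cn(C/C=C3\OC(=O)C(OCc4ccccc4)=C3OCc3ccccc3)nn2)cc1`: > 100000 nM
compound 2, `O=C1O[C@H]([C@@H](O)Cn2cc(-c3cc(F)cc(F)c3)nn2)C(OCc2ccccc2)=C1OCc1ccccc1`: 11600 nM
compound 3, `O=C1O[C@H]([C@@H](O)Cn2cc(CNS(=O)(=O)c3ccc(Cl)cc3F)nn2)C(OCc2ccccc2)=C1OCc1ccccc1`: 25500 nM

In a functional assay on HepG2 cells (Homo sapiens) for antiproliferative activity, read by MTT assay, with a stated time of 72 h (on this read-out lower numbers stand for stronger inhibition and higher numbers for weaker inhibition), compound 1 reaches only a limit of the assay, > 100000 nM (the limit of > 100000 nM in this assay, at which 1 of the 3 values shown sits). Among the two real numbers, compound 2 holds the lower one, and compound 3 sits beyond the scatter from it with a higher number. For the measured compounds named here, no step between compounds that differ in one place is recorded, so the change from compound 2 to compound 4, `COc1ccccc1-c1cn(C[C@H](O)[C@H]2OC(=O)C(OCc3ccccc3)=C2OCc2ccccc2)nn1`, namely (2-methoxyphenyl in place of 3,5-difluorophenyl on an aromatic carbon), has no measured counterpart among the three. The account expects a step from compound 2 to compound 4 of a 1.3-fold higher number from compound 2 to compound 4 (0.11 log units; within the scatter), none beyond the scatter. Compound 4 is therefore estimated at 15000 nM, within 5000 nM to 60000 nM.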

Compound 4, half-maximal inhibitory concentration: > 100000 nM
Compound 4 gave a limit, no number; the forecaster's own chance of this, stated with the estimate: 15%; middle value at least 6.6-fold (0.82 log units) from the limit.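

The group on this aromatic carbon of the five-membered ring with 3 nitrogen clearly matters in this assay: 2-methoxyphenyl in place of 3,5-difluorophenyl gives an at least 8.6-fold higher number from compound 2 to compound 4 (0.93 log units; beyond the scatter). Two aromatic groups of equal heavy-atom count are therefore not interchangeable here. Compound 4 reaches only a limit of the assay, so the full size of this step stays unknown: the limit of > 100000 nM in this assay, at which 2 of the 4 values shown sit.

The compounds shown leave open whether the loss comes from removing the two fluorines or from adding the methoxy group, since both change in one step. A plain phenyl group at this place would separate the two.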